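The source may hold more compounds than are shown below. What is called first, only, known or untested is meant among the compounds shown, and "the series" means these compounds.

Compound 1, `C=C(Cl)C(=O)Nc1ccccc1`, carries a chloro group on the double-bonded chain carbon bound to the carbonyl carbon of the shared core. In an ADME assay for pharmacokinetics, read by LC-MS, in phosphate buffer, with a stated time of 120 min, at pH 7.4, tested at 1 uM, in the presence of a further agent that is not named here (on this read-out higher numbers stand for a longer-lived compound and lower numbers for a shorter-lived compound), compound 1 gives 0.05 h, the only plain number among the two results shown. Compound 2, `COC(=O)CN(C)C/C=C/C(=O)Nc1ccccc1`, is recorded in this assay at > 8.53 h, which is a limit of the assay rather than a number, and it sits at the limit of > 8.53 h in this assay, at which 1 of the 2 values shown sits. Compound 3, `C=C(CO)C(=O)Nc1ccccc1`, has not yet been measured; it differs from compound 1 in one place: hydroxymethyl in place of chloro on a double-bonded chain carbon bound to a carbonyl carbon. Going by the values given here, no step between two measured compounds is available to set a scale for this change. The step from compound 1 to compound 3 is nonetheless expected to be large and in the direction of a longer-lived compound, a 40-fold higher number from compound 1 to compound 3 (1.60 log units; beyond the scatter). For compound 3 in this assay the estimate is 2 h, with a range from 0.3 h to 12 h.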

Compound 3, half-life: > 8.53 h
Compound 3: only a limit was reported; the forecaster's own chance of this, stated with the estimate: 15%; middle value at least 4.2-fold (0.62 log units) away from the limit.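

Going by these compounds alone, at this position, on a double-bonded chain carbon bound to a carbonyl carbon, the earlier compounds offered no step, and this change supplies the first one in this assay. Hydroxymethyl in place of chloro gives an at least 170-fold higher number from compound 1 to compound 3 (2.23 log units; beyond the scatter) and so shows that one change at this single place can carry the compound from a measurable half-life to the end of the readable range. Compound 3 is recorded at > 8.53 h, which is a limit of the assay and not a number, and that limit is now shared: the limit of > 8.53 h in this assay, at which 2 of the 3 values shown sit.

On these data alone, how far the half-life of compound 3 lies past this limit remains open, so the full size of the step stays unknown. Also open, as far as these compounds go, is whether an amine, a carboxylic acid or a longer chain at this place would reach the same limit or stay nearer to compound 1.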